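Hydrazone Variation on a Nitrothiophenyl Thiazole Core

The source may hold more compounds than are shown below. What is called first, only, known or untested is meant among the compounds shown, and "the series" means these compounds.

Measured compounds:
compound 1 `CC(C)=NNc1nc(-c2cccc([N+](=O)[O-])c2)cs1`: 1070 nM
compound 2 `CCC/C(CC)=N\Nc1nc(-c2cccc([N+](=O)[O-])c2)cs1`: 4860 nM

In an assay on isolated protein for inhibition of Amine oxidase [flavin-containing] A (Homo sapiens), read by fluorescence, with a stated time of 20 min (on this read-out higher numbers stand for weaker inhibition and lower numbers for stronger inhibition), compound 1 gives 1070 nM, the lowest of the two numbers; compound 2, with its larger open chain on the same nitrogen, gives 4860 nM. For the measured compounds named here, the one measured step, a 4.5-fold higher number from compound 1 to compound 2 (0.66 log units; beyond the scatter), shows that enlarging this group weakened inhibition.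

Compound 3 `C/C(=N/Nc1nc(-c2cccc([N+](=O)[O-])c2)cs1)C1CC1` differs from compound 1 as follows: a group of 6 heavy atoms (5 carbon, 1 nitrogen; one three-membered non-aromatic ring of carbon only) in place of a group of 4 heavy atoms (3 carbon, 1 nitrogen; no ring), on a nitrogen on an aromatic ring. This enlargement is smaller than that of compound 2, so a smaller weakening is expected, a 1.9-fold higher number from compound 1 to compound 3 (0.27 log units; within the scatter), because of a 4.5-fold higher number from compound 1 to compound 2 (0.66 log units; beyond the scatter). Compound 3 is thus expected to give about 2000 nM in this assay, within 900 nM to 5000 nM.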

Compound 3, half-maximal inhibitory concentration: 2660 nM
For compound 3 the middle estimate is 1.3-fold (0.12 log units) below the measured one; the measured number falls inside the stated range.
By their numbers in this assay, from the lowest: compound 1; then compounds 3 and 2 (each within the scatter of the next).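

In this assay, a three-membered carbon ring also weakens inhibition relative to the smaller group of compound 1, a 2.5-fold higher number from compound 1 to compound 3 (0.40 log units; beyond the scatter), so the loss seen with the open chain is not confined to that chain. Against the open chain of compound 2, the step is a 1.8-fold lower number from compound 2 to compound 3 (0.26 log units; within the scatter), so the ring and the open chain cannot be told apart here. No measurement shown explains either step.

On these data alone, whether a phenyl ring or a group carrying an amine, in this same place, would match or pass compound 1 remains open.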